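A few compounds are considered here, and "the series" means these few. Any claim that something is new, unique, unknown or untested is made for them only; others in the source may bear on it.

Measured compounds:
Compound 1 `COc1ccc(/C=C2/CN(C)/C(=N/c3ccc(C(C)(C)C)cc3)S2)cc1`: 28700 nM
Compound 2 `COc1ccc(/C=C2\S/C(=N\c3ccc(C)c(Cl)c3)N(C)C2=O)cc1`: > 100000 nM (a limit of the assay, not a number)

For the measured compounds named here, in a functional assay on MCF7 cells (Homo sapiens) for antiproliferative activity, read by MTT assay, with a stated time of 72 h (a lower number here means a stronger inhibitor, a higher number a weaker inhibitor), compound 1 gives 28700 nM, the only actual number so far. Compound 2 has only a limit, > 100000 nM, so it offers no exact point of comparison.

Compound 3 `COc1ccc(/C=C2/CN(C)/C(=N/c3ccc(Cl)cc3)S2)cc1` has not yet been measured. It keeps the core of compound 1 but has chloro in place of tert-butyl on an aromatic carbon, para to a large group (chloro in place of tert-butyl on an aromatic carbon). Going by the values given here, no measured pair here shows what this swap does, so the data give no basis for predicting a shift in either direction. In this assay, the expected result is a 1.1-fold higher number from compound 1 to compound 3 (0.05 log units; within the scatter), a step no larger than the usual scatter. For compound 3, the estimated value is 32000 nM, with an expected range of 11000 nM to 90000 nM.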

Compound 3, half-maximal inhibitory concentration: 7600 nM
For compound 3 the middle estimate is 4.2-fold (0.62 log units) above the measured one; the whole stated range lies above it.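

In this assay, for the compounds shown here, chloro in place of tert-butyl gives a 3.8-fold lower number from compound 1 to compound 3 (0.58 log units; beyond the scatter) and provides the first measured change on the core of compound 1. It shows that the group at this place, para to a large group, can change the antiproliferative reading by more than the usual scatter, with chloro giving the stronger result of these two groups. The data shown do not explain why the number moves.

A single swap cannot show whether the outcome follows from the count of heavy atoms or from something else about chloro and tert-butyl. As far as these compounds go, it remains open how a fluoro, a methoxy or an amine would behave at this same place, and whether any of them would move the number further in the same direction.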